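This account rests on a few compounds, and the source may have more. Where it says the series, first, only, none or still open, it means among the compounds named here.

Compound 1, `O=C(O)Cn1c(SCCCCOc2ccccc2)nc2ccccc21`, in an assay on HEK293 cells for displacement of a labelled ligand from prostaglandin D2 receptor 2 (Homo sapiens) (a lower number here means a stronger inhibitor, a higher number a weaker inhibitor), gives 1400 nM.
Compound 2, `O=C(O)Cn1c(SCCCNc2ccccc2)nc2ccccc21`, in this assay gives 2690 nM.
Compound 3, `CCCCCSc1nc2ccccc2n1CC(=O)O`, in this assay gives 1240 nM.

Compound 3 shows the lowest of the three numbers; compound 1 sits within the scatter of it, while compound 2 lies beyond, as the step of a 2.2-fold lower number from compound 2 to compound 3 (0.34 log units; beyond the scatter) shows. Compound 4, `Cc1ccc(CSc2nc3ccccc3n2CC(=O)O)cc1`, differs from compound 3 by 4-methylphenyl in place of butyl on a saturated chain carbon bound to a sulfur. The measured steps that come closest to this both trade an aromatic group for a plain chain further along: a 1.1-fold lower number from compound 1 to compound 3 (0.05 log units; within the scatter) and a 2.2-fold lower number from compound 2 to compound 3 (0.34 log units; beyond the scatter), both small. An aromatic ring placed directly on the chain carbon bound to sulfur is not covered, so no step beyond the scatter is expected in this assay. Compound 4 is therefore estimated at 1300 nM, within 500 nM to 3500 nM, meaning an expected step of a 1.0-fold higher number from compound 3 to compound 4 (0.02 log units; within the scatter).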

Compound 4, half-maximal inhibitory concentration: 220 nM
For compound 4 the middle estimate is 5.9-fold (0.77 log units) above the measured one, outside the stated range (below it).
By their numbers in this assay, from the lowest: compound 4; then compounds 3, 1 and 2 (each within the scatter of the next, the first and the last beyond it).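

Putting 4-methylphenyl in place of butyl on a saturated chain carbon bound to a sulfur gives a 5.6-fold lower number from compound 3 to compound 4 (0.75 log units; beyond the scatter) in this assay. The earlier steps shown here, which exchanged aromatic groups three or four bonds along the chain from a sulfur, were much smaller, so this position responds more strongly to this change than those steps suggested. No measurement shown here accounts for the gain.

As far as these compounds go, it remains open whether the ring alone is enough or the methyl on it also contributes, as a plain phenyl would show. A pyridine ring or a 4-chlorophenyl group at this place is equally untested in the compounds shown.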